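Removing a chloro group from the longer-lived compound

A few compounds are considered here, and "the series" means these few. Any claim that something is new, unique, unknown or untested is made for them only; others in the source may bear on it.

In an in vivo ADME assay on the whole organism (strain Sprague-Dawley) for metabolic stability, with Rattus norvegicus as the target (a lower number here means that the compound disappears faster, a higher number that the compound lasts longer), compound 1 `CN1CCc2cc(N3CC[C@H](NS(=O)(=O)/C=C/c4ccc(Cl)s4)C3=O)ccc2C1` gives 0.4 h, while compound 2 `O=C1[C@@H](NS(=O)(=O)c2ccc3c(Cl)c[nH]c3c2)CCN1c1ccc2c(c1)CCNC2` gives 6.3 h, the higher of the two numbers and beyond the scatter. Compound 3 `O=C1[C@@H](NS(=O)(=O)c2ccc3cc[nH]c3c2)CCN1c1ccc2c(c1)CCNC2` differs from compound 2 in one place: hydrogen in place of chloro on an aromatic carbon, with hydrogen in place of chloro on an aromatic carbon, turning 3-chloro-1H-indol-6-yl into 1H-indol-6-yl. Going by the values given here, no measured pair shows this change, so the expectation is uncertain. A small fall within the scatter is expected in this assay, an estimated 1.8-fold lower number from compound 2 to compound 3 (0.26 log units; within the scatter). The expected half-life of compound 3 is 3.5 h, with an estimated range of 1.2 h to 8 h.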

Compound 3, half-life: 6.1 h
The estimate for compound 3 lay 1.7-fold (0.24 log units) below the measured number; the measured number falls inside the stated range.
By their numbers in this assay, from the lowest: compound 1; then compounds 3 and 2 (each within the scatter of the next).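

In this assay, going by these compounds alone, hydrogen in place of chloro on this aromatic carbon gives a 1.0-fold lower number from compound 2 to compound 3 (0.01 log units; within the scatter) and is the first step here that can be read at a single place. It shows that the long half-life of compound 2 does not need the chloro group, since compound 3, with the plain 1H-indol-6-yl, stays within the scatter of it. Nothing at hand gives a reason for this result.

From the compounds shown here alone, whether a methyl group or a nitrile on the same carbon would keep the half-life in this range stays open. So does whether the same swap would behave alike on another core.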